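Uronamide nitrogen: methyl to isopropyl in compound 4

The source may hold more compounds than are shown below. What is called first, only, known or untested is meant among the compounds shown, and "the series" means these compounds.

Three compounds of this series have numbers in a functional assay on the whole organism with Canis familiaris (Canis lupus familiaris) as the target; a lower number here means that less compound is needed, a higher number that more compound is needed for the effect. Compound 1 `CCC(CC)Nc1ncnc2c1ncn2C1O[C@H](C(=O)NC)[C@@H](O)[C@H]1O` gives 0.24 nM, the lowest of the three. Compound 3 `CCNC(=O)[C@H]1OC(n2cnc3c(NC4CCCCC4)ncnc32)[C@H](O)[C@@H]1O` gives 1.6 nM, and compound 2 `COc1ccc(Nc2ncnc3c2ncn3C2O[C@H](C(=O)O)[C@@H](O)[C@H]2O)cc1` gives 2 nM; both stand above compound 1 by more than the usual scatter, so compound 1 is the most potent of the measured set. Going by the values given here, compounds 2 and 3 differ from compound 1 in more than one place, so no single step between them can be read from these numbers.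

Compound 4 `CCC(CC)Nc1ncnc2c1ncn2C1O[C@H](C(=O)NC(C)C)[C@@H](O)[C@H]1O` is not yet measured. It differs from compound 1 in one place: isopropyl in place of methyl on an amide-type nitrogen. Among the measured compounds only compound 1 and compound 3 carry an amide-type nitrogen with a small alkyl group, and the change from methyl to isopropyl has no direct counterpart in the data, so the direction of the step rests on the shape of the series alone.

The expectation for compound 4 in this assay is a modest loss, with the step of a 6.3-fold higher number from compound 1 to compound 4 (0.80 log units; beyond the scatter) expected to lie just beyond the scatter. Compound 4 is estimated at 1.5 nM, within the range 0.4 nM to 6 nM.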

Compound 4, half-maximal effective concentration: 0.23 nM
Beside the measured number, compound 4's estimate is 6.5-fold (0.81 log units) above it; the whole stated range lies above it.
By their numbers in this assay, from the lowest: compounds 4 and 1 (each within the scatter of the next); then compounds 3 and 2 (each within the scatter of the next).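

Isopropyl in place of methyl on an amide-type nitrogen gives a 1.0-fold lower number from compound 1 to compound 4 (0.02 log units; within the scatter) in this assay, and this is the only single-place step in the compounds shown. Going by these compounds alone, at this position on the core of compound 1, the number therefore does not separate methyl from isopropyl, so the extra carbons of the isopropyl group carry no readable penalty or gain in this whole-organism read-out, a finding that the earlier compounds, which differ from one another in more than one place, could not give. Nothing at hand accounts for this result.

From the compounds shown here alone, it remains open how far this tolerance extends, since a longer chain such as n-butyl, a ring such as cyclopentyl or benzyl, or the unsubstituted carboxamide could each stay within the scatter of compound 1 or fall clearly outside it. Going by these compounds, it also remains open whether the same change reads the same way on a core carrying another amino group, such as the cyclohexylamino group of compound 3, as the present step comes from a single core.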